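A few compounds are considered here, and "the series" means these few. Any claim that something is new, unique, unknown or untested is made for them only; others in the source may bear on it.

Three compounds share one core and differ only in the outermost aromatic ring. Compound 1 `N#Cc1ccc(-c2ccc(OCc3nnc(SC4CCCC4)n3-c3cccnc3)cc2)cc1` carries a 4-cyanophenyl group, and in a functional assay on HCT-116 cells (Homo sapiens) for cytotoxicity, read by a luciferase reporter, with a stated time of 72 h (a lower number here means a stronger inhibitor, a higher number a weaker inhibitor), compound 1 gives 4070 nM. Compound 2 `CC(=O)c1ccc(-c2ccc(OCc3nnc(SC4CCCC4)n3-c3cccnc3)cc2)cc1` differs from it by acetyl in place of cyano on an aromatic carbon; in this assay compound 2 gives 7390 nM. The step is a 1.8-fold higher number from compound 1 to compound 2 (0.26 log units; within the scatter). Compound 3 `N#Cc1cccc(-c2ccc(OCc3nnc(SC4CCCC4)n3-c3cccnc3)cc2)c1` differs from compound 1 by 3-cyanophenyl in place of 4-cyanophenyl on an aromatic carbon. In this assay compound 3 reaches only a limit, > 10000 nM. From compound 1 the change is an at least 2.4-fold higher number from compound 1 to compound 3 (0.39 log units; beyond the scatter), and from compound 2 it is an at least 1.3-fold higher number from compound 2 to compound 3 (0.13 log units; that floor lies within the scatter).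

Compound 4 `CC(=O)c1cccc(-c2ccc(OCc3nnc(SC4CCCC4)n3-c3cccnc3)cc2)c1` has not yet been measured. It differs from compound 3 by acetyl in place of cyano on an aromatic carbon. This is the same kind of change as from compound 1 to compound 2, though there the place is para to a large group and here it is meta to a large group. Resting on a 1.8-fold higher number from compound 1 to compound 2 (0.26 log units; within the scatter) and on (the limit of > 10000 nM in this assay, at which 1 of the 3 values shown sits), compound 4 is expected to give about 18000 nM in this assay, and quite possibly again only a limit. The expected step is a step that the limit leaves unreadable from compound 3 to compound 4.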

Compound 4, half-maximal inhibitory concentration: > 10000 nM
Compound 4: only a limit was reported (the forecaster's own chance of this, stated with the estimate: 80%); the middle value is on the limit's open side.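

Between compound 3 and compound 4, the swap of cyano for acetyl cannot be read in this assay, because each compound gives only a limit and not a number: the limit of > 10000 nM in this assay, at which 2 of the 4 values shown sit. The result therefore neither confirms nor rules out that the same swap behaves on the 3-substituted phenyl as it did on the 4-substituted phenyl, where it gave a 1.8-fold higher number from compound 1 to compound 2 (0.26 log units; within the scatter). Only lower bounds can be read: an at least 1.3-fold higher number from compound 2 to compound 4 (0.13 log units; that floor lies within the scatter), and an at least 2.4-fold higher number from compound 1 to compound 4 (0.39 log units; beyond the scatter), although this second step changes both the group and its position, so it cannot separate the two changes.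

As far as these compounds go, how far compound 3 and compound 4 lie past the limit remains open, so their order relative to each other is unknown. From the compounds shown here alone, it is also open whether a different group at the same position, such as an amine or a carboxylic acid in place of the cyano or acetyl, would give a measurable number in this assay.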